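Working notes: from compound 3 to compound 4

The compounds below may be only part of what the source reports. "The series", "measured", "known", "first", "only" and "open" are said of these compounds alone.

Measured in a functional assay on HT-29 cells (Homo sapiens) for cytotoxicity, read by sulforhodamine B assay, with a stated time of 48 h; on this read-out higher numbers stand for weaker inhibition and lower numbers for stronger inhibition:

compound 1 `O=C(CCCCCN1C(=O)CC(SCCOCCOCCOc2cc(O)c(C(=O)CCc3ccc(O)cc3)c(O)c2)C1=O)OCn1cc(F)c(=O)[nH]c1=O` — 43700 nM
compound 2 `O=C(CCCSSCCOCCOCCOc1cc(O)c(C(=O)CCc2ccc(O)cc2)c(O[C@@H]2O[C@H](CO)[C@@H](O)[C@H](O)[C@H]2O)c1)OCn1cc(F)c(=O)[nH]c1=O` — 59800 nM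
compound 3 `O=C(CCCc1cn(CCOCCOCCOc2cc(O)c(C(=O)CCc3ccc(O)cc3)c(O[C@@H]3O[C@H](CO)[C@@H](O)[C@H](O)[C@H]3O)c2)nn1)OCn1cc(F)c(=O)[nH]c1=O` — > 100000 nM

Compound 1 and compound 2 give numbers in this assay. For compound 3 the read-out is only a limit, (the limit of > 100000 nM in this assay, at which 1 of the 3 values shown sits), so its position within the series cannot be placed more exactly than that. Compound 4 `O=C(CCCc1cn(CCOCCOCCOc2cc(O)c(C(=O)CCc3ccc(O)cc3)c(O)c2)nn1)OCn1cc(F)c(=O)[nH]c1=O` differs from compound 3 in one place: hydrogen in place of 3,4,5-trihydroxy-6-(hydroxymethyl)oxan-2-yl on an oxygen on an aromatic ring. Going by the values given here, no measured pair differs in this change alone; compound 1 and compound 2 differ both in the linker and in this group, so their two values settle nothing about it. A small step toward stronger inhibition is expected, an at least 1.4-fold lower number from compound 3 to compound 4 (0.15 log units; that floor lies within the scatter), and a limit again is a real possibility. Compound 4 is estimated at 70000 nM, within 30000 nM to 160000 nM.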

Compound 4, half-maximal inhibitory concentration: 85000 nM
Compound 4: middle estimate off by 1.2-fold (0.08 log units), on the low side; the measured number falls inside the stated range.
By their numbers in this assay, from the lowest: compounds 1, 2 and 4 (each within the scatter of the next). At a limit, above all of these: compound 3.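

In this assay, going by these compounds alone, the replacement of 3,4,5-trihydroxy-6-(hydroxymethyl)oxan-2-yl by hydrogen on an oxygen on an aromatic ring can now be read alone, which the earlier compounds did not allow: it gives an at least 1.1-fold lower number from compound 3 to compound 4 (0.07 log units; that floor lies within the scatter). Compound 3 stands at a limit, so only a floor is known for this step, and the true size of the change remains unresolved: the limit of > 100000 nM in this assay, at which 1 of the 4 values shown sits.

Open, going by these compounds, is what a methyl ether or an acetic acid chain on this oxygen would give. Also open, on these data alone, is whether the change reads the same with other linkers.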